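A few compounds are considered here, and "the series" means these few. Any claim that something is new, unique, unknown or untested is made for them only; others in the source may bear on it.

The measured compounds are:

compound 1 `NC(C(=O)O)c1cnn(O)c1Br` — > 1000000 nM
compound 2 `CCc1c(C(N)C(=O)O)cnn1O` — > 1000000 nM

In a functional assay on CHO cells for agonist activity at metabotropic glutamate receptor 1 (Rattus norvegicus), read by calcium flux (a lower number here means that less compound is needed, a higher number that more compound is needed for the effect), compound 1 gives > 1000000 nM, which is a limit of the assay rather than a number. Compound 2 gives > 1000000 nM in this assay, again only a limit. Compound 2 therefore stands on no measured number at all; both values shown sit at the limit of > 1000000 nM in this assay, at which 2 of the 2 values shown sit, and the step that the two limits leave unreadable from compound 1 to compound 2 cannot be read from them.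

Compound 3 `CCCc1c(C(N)C(=O)O)cnn1O` differs from compound 2 by methyl in place of hydrogen on a saturated chain carbon, two bonds along the chain from an aromatic carbon. Among the measured compounds shown here, the only measured step that bears on this change is the one from compound 1 to compound 2, and its size is not readable, so no direction and no size of step can be drawn from it for the move to compound 3. Both compounds shown sit at the limit, and nothing in the data points to a response from compound 3 either.

Compound 3 is therefore expected to give about 1000000 nM in this assay, most likely again only as a limit, with a range from 300000 nM to 3000000 nM. The step from compound 2 to compound 3 is expected to be a number no higher from compound 2 to compound 3 (the limit leaves the size open), that is, no readable change.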

Compound 3, half-maximal effective concentration: > 1000000 nM
Compound 3 gave a limit, no number (the forecaster's own chance of this, stated with the estimate: 85%); the middle value lies on the limit itself.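

In this assay compound 3 gives > 1000000 nM, which is again a limit of the assay and not a number. Among the compounds shown here, no step among compound 1, compound 2 and compound 3 can therefore be read, and all three stand at the same limit: the limit of > 1000000 nM in this assay, at which 3 of the 3 values shown sit. The compounds shown leave open whether bromo, ethyl or propyl makes any difference to the response.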